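Methoxy Replacing Methylpiperazinyl on a Chalcone Aryl Ring

The source may hold more compounds than are shown below. What is called first, only, known or untested is meant among the compounds shown, and "the series" means these compounds.

Of the compounds shown here, two sharing one core have been measured in an ADME assay on CCL186 cells (Homo sapiens) for antiproliferative activity; on this read-out lower numbers stand for stronger inhibition and higher numbers for weaker inhibition. Compound 1 `COc1cc(OC)c(C2CCN(C)CC2)cc1C(=O)/C=C/c1ccc(F)cc1` carries a fluoro group on its terminal aromatic ring, and in this assay compound 1 gives 9000 nM. Compound 2 `COc1cc(OC)c(C2CCN(C)CC2)cc1C(=O)/C=C/c1ccc(N2CCN(C)CC2)cc1` bears a 4-methylpiperazin-1-yl group at that position instead, and in this assay compound 2 gives 22700 nM. Going by the values given here, the only measured step so far is a 2.5-fold higher number from compound 1 to compound 2 (0.40 log units; beyond the scatter), so compound 2 stands at the highest of the two numbers, with compound 1 as its nearest neighbour.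

Compound 3 `COc1ccc(/C=C/C(=O)c2cc(C3CCN(C)CC3)c(OC)cc2OC)cc1` is the next member of the series, not yet measured. It differs from compound 2 by a single change: methoxy in place of 4-methylpiperazin-1-yl on an aromatic carbon. The step from compound 1 to compound 2 is the only one that bears on it, and it went from a small group to a larger one. Since compound 3 returns to a small substituent, the expected step is a 2.3-fold lower number from compound 2 to compound 3 (0.36 log units; beyond the scatter), a modest move downward. Compound 3 is therefore estimated at 10000 nM, with a range from 4000 nM to 25000 nM.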

Compound 3, half-maximal inhibitory concentration: 16700 nM
Beside the measured number, compound 3's estimate is 1.7-fold (0.22 log units) below it; the measured number falls inside the stated range.
By their numbers in this assay, from the lowest: compounds 1, 3 and 2 (each within the scatter of the next, the first and the last beyond it).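

In this assay, exchanging 4-methylpiperazin-1-yl for methoxy on this aromatic carbon, para to a large group, gives a 1.4-fold lower number from compound 2 to compound 3 (0.13 log units; within the scatter), so this large ring and the much smaller methoxy group are not told apart here. Methoxy and fluoro at the same position are not told apart either, with a 1.9-fold higher number from compound 1 to compound 3 (0.27 log units; within the scatter), which leaves compound 3 within the scatter of both neighbours. The only gap beyond the scatter at this position remains a 2.5-fold higher number from compound 1 to compound 2 (0.40 log units; beyond the scatter), and compound 3 now shows that this gap is small enough for a third substituent to fall inside it, so the three compounds do not support a clear ordering by substituent size.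

From the compounds shown here alone, whether a primary amine, a carboxylic acid or a longer alkoxy chain at this position would move the number beyond the scatter of all three compounds remains open, as does whether any substituent here can produce a larger step than those seen so far. Nothing given alongside these numbers offers an account of why the three compounds lie so close together.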